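This account rests on a few compounds, and the source may have more. Where it says the series, first, only, none or still open, it means among the compounds named here.

In a functional assay on KB cells (Homo sapiens) for cytotoxicity (on this read-out higher numbers stand for weaker inhibition and lower numbers for stronger inhibition), compound 1 `COc1ccc(S(=O)(=O)N2CCc3cccc(NC(=O)Oc4ccccc4)c32)cc1` gives > 10000 nM, which is a limit of the assay and not a number. That places compound 1 at the limit of > 10000 nM in this assay, at which 1 of the 3 values shown sits. Compound 2 `COc1ccc(S(=O)(=O)N2CCc3cc(Br)cc(NC(=O)c4ccco4)c32)cc1` gives 89 nM, and compound 3 `COc1ccc(S(=O)(=O)N2CCc3cc(Br)cc(NC(=O)c4ccncc4)c32)cc1` gives 91 nM, but both also differ from compound 1 on the core.

The next compound to be tested is compound 4 `COc1ccc(S(=O)(=O)N2CCc3cccc(NS(=O)(=O)c4ccccc4)c32)cc1`, which differs from compound 1 as follows: phenylsulfonyl in place of phenoxycarbonyl on a nitrogen on an aromatic ring. In words, phenylsulfonyl takes the place of phenoxycarbonyl on a nitrogen on an aromatic ring.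

Within the data shown here, only one measured step comes close to this change: a 1.0-fold higher number from compound 2 to compound 3 (0.01 log units; within the scatter). That step exchanges pyridin-4-yl for furan-2-yl on a carbonyl carbon and stays within the scatter, but it leaves the carbonyl in place, so it offers only weak guidance here. Among the measured compounds shown here, no measured step removes the carbonyl, so the forecast is loose: a shift towards stronger inhibition is possible, yet compound 4 could also stay at the limit. The expected change is an at least 2.5-fold lower number from compound 1 to compound 4 (0.39 log units; beyond the scatter). For compound 4 the estimated value is 4000 nM, with an expected range from 500 nM to 10000 nM.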

Compound 4, half-maximal inhibitory concentration: 650 nM
The estimate for compound 4 lay 6.2-fold (0.79 log units) above the measured number, within the range that was stated.
By their numbers in this assay, from the lowest: compounds 2 and 3 (each within the scatter of the next); then compound 4. At a limit, above all of these: compound 1.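

Among these compounds, on the nitrogen on an aromatic ring, the earlier compounds gave no step that removed the carbonyl, and here phenylsulfonyl in place of phenoxycarbonyl gives an at least 15-fold lower number from compound 1 to compound 4 (1.18 log units; beyond the scatter) in this assay. Compound 1 gives > 10000 nM, which is a limit of the assay and not a number, so only a lower bound on the size of this step can be read. The two groups have the same count of heavy atoms and each carries one six-membered aromatic ring of carbon only, so this one exchange shows that the read-out responds to the group at this position.

Still open, on these data alone, is how a methylsulfonyl group or a free amine on this nitrogen would read, which would test whether the phenyl ring is needed. Also open, as far as these compounds go, is whether phenylsulfonyl would give a similar step on the bromine-bearing core of compound 2 and compound 3.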